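Furan-3-ylmethylamine on the piperidine carbon: compound 4

The compounds below may be only part of what the source reports. "The series", "measured", "known", "first", "only" and "open" are said of these compounds alone.

Measured compounds:
compound 1 `c1ccc(C2CCCCN2C2CCN(CCCc3c[nH]c4ccc(-n5cnnc5)cc34)CC2)cc1` — 1.9 nM
compound 2 `CN(Cc1ccccc1)CC1CCN(CCCc2c[nH]c3ccc(-n4cnnc4)cc23)CC1` — 0.9 nM
compound 3 `CN(CC1CCN(CCCc2c[nH]c3ccc(-n4cnnc4)cc23)CC1)C(=O)Nc1ccccc1` — 5.9 nM

Among the compounds with values here, in an assay on CHO cells for displacement of a labelled ligand from 5-hydroxytryptamine receptor 1D (Homo sapiens) (a higher number here means a weaker inhibitor, a lower number a stronger inhibitor), compound 2 gives the lowest number of the three; compound 1 sits nearest, compound 3 furthest, the step of a 6.6-fold higher number from compound 2 to compound 3 (0.82 log units; beyond the scatter) being the one measured step in the set. Compound 4 `c1cc(CNC2CCN(CCCc3c[nH]c4ccc(-n5cnnc5)cc34)CC2)co1` differs from compound 2 by ((furan-3-yl)methyl)amino in place of (benzyl(methyl)amino)methyl on a saturated ring carbon. Within the data shown here, no measured step touches this change: the only step replaces one substituent on the amine nitrogen, whereas here the whole side group on the saturated ring carbon is exchanged. Compound 1, which also carries a nitrogen directly on that ring carbon, stays close to compound 2. The step of a 3.3-fold higher number from compound 2 to compound 4 (0.52 log units; beyond the scatter) is therefore expected to be a modest weakening. Compound 4 is estimated at 3 nM, within 0.8 nM to 12 nM.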

Compound 4, half-maximal inhibitory concentration: 4.5 nM
Compound 4: middle estimate off by 1.5-fold (0.18 log units), on the low side; the measured number falls inside the stated range.
By their numbers in this assay, from the lowest: compound 2; then compound 1; then compounds 4 and 3 (each within the scatter of the next).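

In this assay the exchange on the saturated ring carbon gives a 5.0-fold higher number from compound 2 to compound 4 (0.70 log units; beyond the scatter) and shows that this position keeps a low number with a smaller side group, a five-membered aromatic ring in place of the six-membered one, and an added hydrogen-bond donor. This single pair changes all of these features at once and cannot assign the step to any one of them. No available evidence bears on the origin of the step.

Still open, going by these compounds, is how a thiophene ring in place of the furan would read on the same amino link. On these data alone, the effect of a longer chain between that amine and the ring also remains open.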